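A Dimethoxyphenyl Replaces the Nitrophenyl Arm

The compounds below may be only part of what the source reports. "The series", "measured", "known", "first", "only" and "open" are said of these compounds alone.

Of the compounds shown here, three sharing one core have been measured in a functional assay on A549 cells (Homo sapiens) for cytotoxicity, read by MTT assay, with a stated time of 72 h; a higher number here means a weaker inhibitor, a lower number a stronger inhibitor. Compound 1 `O=C(/C=C/c1ccc([N+](=O)[O-])cc1)Nc1cc2c(Nc3ccc(F)c(Cl)c3)ncnc2cc1O[C@H]1CCOC1` carries a 4-nitrophenyl on a double-bonded chain carbon bound to a double-bonded chain carbon, and in this assay compound 1 gives 12000 nM, the highest number of the three. Compound 2 `COc1ccc(OC)c(/C=C/C(=O)Nc2cc3c(Nc4ccc(F)c(Cl)c4)ncnc3cc2OC)c1` gives 11200 nM, a value that lies within the scatter of the number for compound 1. Compound 3 `COc1ccc(/C=C/C(=O)Nc2cc3c(Nc4ccc(F)c(Cl)c4)ncnc3cc2O[C@H]2CCOC2)c(OC)c1OC` gives 70 nM, and a 170-fold lower number from compound 1 to compound 3 (2.23 log units; beyond the scatter), a single exchange of 2,3,4-trimethoxyphenyl for 4-nitrophenyl.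

Compound 4 `COc1cc(/C=C/C(=O)Nc2cc3c(Nc4ccc(F)c(Cl)c4)ncnc3cc2O[C@H]2CCOC2)cc(OC)c1` is not yet measured. Its change from compound 1 is 3,5-dimethoxyphenyl in place of 4-nitrophenyl on a double-bonded chain carbon bound to a double-bonded chain carbon. Among the compounds with values here, the only measured step that bears on this change is the one at the same place, toward compound 3, and it was large. Within the data shown here, compound 2 also carries two methoxy groups on that ring, but it differs from compound 3 in a second place as well, so it offers no single step; its value near that of compound 1 shows that two methoxy groups did not, in that case, bring the gain seen with compound 3. A lower number is therefore expected for compound 4, but with wide uncertainty. The estimate for compound 4 in this assay is 2000 nM, with a range from 200 nM to 15000 nM. This expected result corresponds to a 6.0-fold lower number from compound 1 to compound 4 (0.78 log units; beyond the scatter).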

Compound 4, half-maximal inhibitory concentration: 10800 nM
Beside the measured number, compound 4's estimate is 5.4-fold (0.73 log units) below it; measured number inside the range.
By their numbers in this assay, from the lowest: compound 3; then compounds 4, 2 and 1 (each within the scatter of the next).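

In this assay, the exchange of 4-nitrophenyl for 3,5-dimethoxyphenyl on a double-bonded chain carbon bound to a double-bonded chain carbon gives a 1.1-fold lower number from compound 1 to compound 4 (0.05 log units; within the scatter), so at this place the presence of methoxy groups on the ring does not by itself bring the gain seen with compound 3. The exchange between the two methoxy-bearing rings gives a 150-fold higher number from compound 3 to compound 4 (2.19 log units; beyond the scatter), which ties the gain to the 2,3,4-trimethoxyphenyl of compound 3 and not to the removal of the 4-nitrophenyl, since 3,5-dimethoxyphenyl and 4-nitrophenyl cannot be told apart here. Nothing available explains why the 2,3,4-trimethoxyphenyl stands apart from the other two rings at this place.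

The compounds shown leave open whether all three methoxy groups of the 2,3,4-trimethoxyphenyl are needed, or whether fewer of them would hold a number near that of compound 3 at 70 nM. They also leave open how a ring carrying an amine or a hydroxyl group in place of those methoxy groups would read in this assay.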